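The source may hold more compounds than are shown below. What is called first, only, known or untested is meant among the compounds shown, and "the series" means these compounds.

Measured so far:
- compound 1 `Nc1nc(O)nc2c1nc(O)n2Cc1ccccc1`, 1 mg/kg in a functional assay on the whole organism for activation, with Mus musculus as the target; a higher number here means that more compound is needed for the effect, a lower number that less compound is needed
- compound 2 `Nc1ncnc2c1nc(O)n2Cc1ccc(Cl)cc1`, 30 mg/kg

Compound 1 stands lowest of the two numbers in this assay; the nearest is compound 2, and the gap between the two is beyond the scatter. For the measured compounds named here, no step between measured compounds that differ in one place is available, so the series itself offers no measured guidance for the change at hand.

Compound 3 `Nc1nc(SCc2ccccc2)nc2c1nc(O)n2Cc1ccccc1` is the next candidate. It differs from compound 1 as follows: benzylsulfanyl in place of hydroxy on an aromatic carbon. Going by the values given here, nothing among the measured compounds shows what a replacement of this kind does, and the expectation is accordingly loose: a step of moderate size toward a higher number, that is toward more compound needed, is expected, though a result within the scatter of compound 1 cannot be excluded.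

For compound 3 in this assay the estimate is 3 mg/kg, range 0.7 mg/kg to 20 mg/kg. This estimate means an expected step of a 3.0-fold higher number from compound 1 to compound 3 (0.48 log units; beyond the scatter).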

Compound 3, minimum effective dose: > 1 mg/kg
Compound 3: a limit, no number (the forecaster's own chance of this, stated with the estimate: 15%); the middle value is on the limit's open side.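

In this assay compound 3 gives > 1 mg/kg as its result, which is a limit and not a number. Benzylsulfanyl in place of hydroxy on the aromatic carbon between two ring nitrogen atoms provides the first measured step at this position: a number no lower from compound 1 to compound 3 (the limit leaves the size open) is all that can be stated for this change. The result therefore shows no gain from this replacement on the core of compound 1, while any loss remains unsized, and the series holds just one such limit: the limit of > 1 mg/kg in this assay, at which 1 of the 3 values shown sits.

On these data alone, whether benzylsulfanyl changes the required dose at all in this assay remains open. Also open, as far as these compounds go, is how a smaller group on this carbon, such as methylsulfanyl, methoxy or an amine, would compare with hydroxy on the same core.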